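A few compounds are considered here, and "the series" means these few. Any claim that something is new, unique, unknown or untested is made for them only; others in the source may bear on it.

Measured so far:
Compound 1 `CC1CCCCN1C(=S)SCc1ccc(C(=O)Nc2ccccc2N)cc1`: in a functional assay on MGC-803 cells (Homo sapiens) for antiproliferative activity, read by CCK-8 assay, with a stated time of 72 h, tested at 2 uM (a lower number here means a weaker effect, a higher number a stronger effect of the compound at the concentration tested), compound 1 gives 64.4%.
Compound 2 `Nc1ccccc1NC(=O)c1ccc(CSC(=S)N2CCCc3ccccc32)cc1`: in this assay compound 2 gives 38.5%.
Compound 3 `Nc1ccccc1NC(=O)c1ccc(CSC(=S)N2CCCC2)cc1`: in this assay compound 3 gives 27%.

Compound 3 stands lowest of the three numbers in this assay. Its nearest neighbour is compound 2, through the step of a number 11.5 percentage points lower from compound 2 to compound 3 (beyond the scatter); its furthest is compound 1, through the step of a number 37.4 percentage points lower from compound 1 to compound 3 (beyond the scatter). The two larger groups on the thiocarbonyl carbon thus sit above the pyrrolidin-1-yl of compound 3, and the step of a number 25.9 percentage points lower from compound 1 to compound 2 (beyond the scatter) separates those two from each other.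

Compound 4 `Nc1ccccc1NC(=O)c1ccc(CSC(=S)N2CCc3ccccc32)cc1` is not yet measured. It differs from compound 3 in one place: 2,3-dihydro-1H-indol-1-yl in place of pyrrolidin-1-yl on a thiocarbonyl carbon.

Within the data shown here, the step that bears most on this change is the one from compound 2 to compound 3, where the group that leaves is the same pyrrolidin-1-yl and the group that enters carries a fused six-membered aromatic ring of carbon only, as 2,3-dihydro-1H-indol-1-yl does; run in reverse, a number 11.5 percentage points lower from compound 2 to compound 3 (beyond the scatter) points to a modest rise. The step of a number 37.4 percentage points lower from compound 1 to compound 3 (beyond the scatter) gives the upper end of what a larger group on this carbon has reached. For compound 4 a modest rise in this assay is therefore expected, of about a number 11 percentage points higher from compound 3 to compound 4 (beyond the scatter). Compound 4 is estimated at 38%, within 24% to 54%.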

Compound 4, a percentage reported as inhibition, at one concentration (the size of the read-out at that concentration, not a potency): 44%
Compound 4: middle estimate off by 6 percentage points, on the low side; measured number inside the range.
By their numbers in this assay, from the lowest: compound 3; then compounds 2 and 4 (each within the scatter of the next); then compound 1.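

Among these compounds, in (this assay), the five-membered non-aromatic ring on the thiocarbonyl carbon gains from carrying the six-membered aromatic ring of carbon only (a number 17 percentage points higher from compound 3 to compound 4 (beyond the scatter)), a comparison the earlier compounds did not offer. Between compound 2 and compound 3 the ring size also changed. The two fused groups, 2,3-dihydro-1H-indol-1-yl and 1,2,3,4-tetrahydroquinolin-1-yl, cannot be told apart here (a number 5.5 percentage points higher from compound 2 to compound 4 (within the scatter)), while 2-methylpiperidin-1-yl, with no aromatic ring, stays clearly apart from the new group (a number 20.4 percentage points lower from compound 1 to compound 4 (beyond the scatter)), so among these compounds the fused aromatic ring does not reach the level of compound 1. Nothing on hand gives a reason for these differences.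

Still open, from the compounds shown here alone, is whether the methyl group or the six-membered ring sets compound 1 apart, a question that piperidin-1-yl without the methyl would address. Also open, going by these compounds, is where morpholin-4-yl, with its ring oxygen, or an open-chain diethylamino group would stand on this carbon, and whether this order at one concentration would hold across a full concentration range.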